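Swapping the aryl on the ring nitrogen for an amide-linked fluorophenyl

This account rests on a few compounds, and the source may have more. Where it says the series, first, only, none or still open, it means among the compounds named here.

Three analogues of one shared core have been measured in a functional assay on A549 cells (Homo sapiens) for inhibition, read by MTT assay, with a stated time of 24 h; on this read-out higher numbers stand for weaker inhibition and lower numbers for stronger inhibition. Compound 1 `CCOC(=O)C1=Cc2ccccc2OC1(OCc1cn(-c2ccc(F)cc2)nn1)C(F)(F)F` gives 7300 nM in this assay. Compound 2 `CCOC(=O)C1=Cc2ccccc2OC1(OCc1cn(-c2ccccc2)nn1)C(F)(F)F` reaches > 150000 nM, which is a limit of the assay rather than a number. Compound 3 `CCOC(=O)C1=Cc2ccccc2OC1(OCc1cn(-c2ccc(F)c([N+](=O)[O-])c2)nn1)C(F)(F)F` gives 11900 nM. Of the two numbers, compound 3 sits highest, and its nearest neighbour is compound 1, a gap within the scatter.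

The measured steps were large in both directions: an at least 20-fold higher number from compound 1 to compound 2 (1.31 log units; beyond the scatter) for hydrogen in place of fluoro on an aromatic carbon, and an at least 12-fold lower number from compound 2 to compound 3 (1.10 log units; beyond the scatter) for 4-fluoro-3-nitrophenyl in place of phenyl on an aromatic nitrogen. The step of a 1.6-fold higher number from compound 1 to compound 3 (0.21 log units; within the scatter) for nitro in place of hydrogen on an aromatic carbon was small.

Compound 4 `CCOC(=O)C1=Cc2ccccc2OC1(OCc1cn(CC(=O)Nc2cccc(F)c2)nn1)C(F)(F)F` differs from compound 3 by ((3-fluorophenyl)carbamoyl)methyl in place of 4-fluoro-3-nitrophenyl on an aromatic nitrogen. Within the data shown here, no measured step alters the group on that ring nitrogen in this way; the measured steps only show large moves whenever that aryl was altered. One of them ends at the limit of > 150000 nM in this assay, at which 1 of the 3 values shown sits. A fluorophenyl is kept but set behind a carbamoylmethyl link, so a step of uncertain direction and possibly large size is expected. Compound 4 is therefore estimated at 15000 nM, between 4000 nM and 60000 nM, meaning a 1.3-fold higher number from compound 3 to compound 4 (0.10 log units; within the scatter) with wide uncertainty.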

Compound 4, half-maximal inhibitory concentration: > 150000 nM
Compound 4 was reported as a limit; the forecaster's own chance of this, stated with the estimate: 20%; middle value at least 10-fold (1.00 log units) away from the limit.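

In this assay, the amide-linked chain is the first change shown that replaces the whole aryl on the aromatic nitrogen rather than altering substituents on a directly attached phenyl, and keeping a fluorophenyl in the new group does not preserve the measured inhibition: an at least 12-fold higher number from compound 3 to compound 4 (1.10 log units; beyond the scatter), and an at least 20-fold higher number from compound 1 to compound 4 (1.31 log units; beyond the scatter). Compound 4 gives a limit and not a number, so this position now has a second substituent whose result is a limit: the limit of > 150000 nM in this assay, at which 2 of the 4 values shown sit. The step between compound 2 and compound 4 cannot be read, as both values are limits, so these two cannot be ranked against each other.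

The compounds shown leave open whether the loss at compound 4 belongs to the carbamoylmethyl link or to the fluoro group on the 3-fluorophenyl, since the step from compound 1 changes both together and a 4-fluorophenyl on the same link would separate them. They also leave open how this ring nitrogen would respond to a group of another kind, such as a longer chain ending in an amine or a carboxylic acid.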